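The compounds below may be only part of what the source reports. "The series", "measured", "known", "first", "only" and "open" are said of these compounds alone.

Measured compounds:
- compound 1 `CSc1cccc(NC(=O)C2CCCN(C(=O)c3cc(C(F)(F)F)cc(C(F)(F)F)c3)C2)c1`: 0%
- compound 2 `Cc1nc(-c2cccc(C(=O)N3CCCC(C(=O)Nc4ccc(Cl)cc4)C3)c2)no1`: 0%

In an ADME assay on PC-3 cells (Homo sapiens) for cytotoxicity, read by WST assay, tested at 100 uM (a lower number here means less inhibition, a higher number more inhibition at the concentration tested (going by the name of the read-out)), compound 1 gives 0%. Compound 2 gives 0% in this assay. Compound 1 thus stands level with compound 2 at the digits shown, the gap lying within the scatter.

Compound 3 `Cn1cnnc1-c1cccc(NC(=O)C2CCCN(C(=O)c3cc(C(F)(F)F)cc(C(F)(F)F)c3)C2)c1` differs from compound 1 by 4-methyl-4H-1,2,4-triazol-3-yl in place of methylsulfanyl on an aromatic carbon. Going by the values given here, no measured step of this kind exists, so the step is expected to be a number 2 percentage points higher from compound 1 to compound 3 (within the scatter), none beyond the scatter. Compound 3 is estimated at 2% in this assay, with a range from -8% to 15%.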

Compound 3, a percentage reported as inhibition, at one concentration (the size of the read-out at that concentration, not a potency): 0%
Compound 3: the middle estimate sits 2 percentage points above what was measured; the range from low to high includes it.
By their numbers in this assay, from the lowest: compounds 1, 2 and 3 (each within the scatter of the next).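

In this assay, 4-methyl-4H-1,2,4-triazol-3-yl in place of methylsulfanyl on this aromatic carbon gives no change at the digits printed from compound 1 to compound 3 (within the scatter). This position therefore takes a five-membered aromatic ring with 3 hetero atoms, 6 heavy atoms against 2, with no shift in the read-out beyond the scatter. Nothing available explains this result.

From the compounds shown here alone, whether an amine or a carboxylic acid on the same aromatic carbon would read the same stays open. With all three values level, it is also unknown whether any group here can move this read-out at all.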